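This account rests on a few compounds, and the source may have more. Where it says the series, first, only, none or still open, it means among the compounds named here.

Measured in a functional assay on MCF7 cells (Homo sapiens) for cytotoxicity, read by MTT assay, with a stated time of 24 h; a higher number here means a weaker inhibitor, a lower number a stronger inhibitor:

Compound 1 `Cc1cc(-c2nc3ccccc3o2)ccc1NC(=O)CN1CCN(CCN(C)C)CC1` gives 41600 nM
Compound 2 `CN(C)CCN1CCN(CC(=O)Nc2ccc(-c3nc4ccccc4o3)cc2)CC1` gives 59400 nM
Compound 3 `Cc1cc(-c2nc3ccccc3o2)ccc1NC(=O)CN1CCN(CCCN(C)C)CC1` gives 11300 nM

Among the three, compound 1 sits close to compound 2, the two within the scatter of each other, as the step of a 1.4-fold higher number from compound 1 to compound 2 (0.15 log units; within the scatter) shows for the change of hydrogen in place of methyl on an aromatic carbon. Compound 3 lies below both, with the step of a 3.7-fold lower number from compound 1 to compound 3 (0.57 log units; beyond the scatter) for (dimethylamino)methyl in place of dimethylamino on a saturated chain carbon.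

Compound 4 `Cc1cc(-c2nc3cc(Cl)ccc3o2)ccc1NC(=O)CN1CCN(CCN(C)C)CC1` differs from compound 1 by chloro in place of hydrogen on an aromatic carbon, on a six-membered aromatic ring of carbon only that is part of a fused system of two rings. For the measured compounds named here, neither measured step touches this ring, so no step bears directly on the change; the one change on an aromatic carbon, the step of a 1.4-fold higher number from compound 1 to compound 2 (0.15 log units; within the scatter), stayed within the scatter. Compound 4 is therefore expected to stay near compound 1 in this assay, with a step of a 1.2-fold lower number from compound 1 to compound 4 (0.06 log units; within the scatter). The estimate for compound 4 is 36000 nM, in the range 12000 nM to 100000 nM.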

Compound 4, half-maximal inhibitory concentration: 39300 nM
Estimate against measurement, compound 4: 1.1-fold (0.04 log units) below; low and high end bracket the measured number.
By their numbers in this assay, from the lowest: compound 3; then compounds 4, 1 and 2 (each within the scatter of the next).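

In this assay, compound 4 is the first of the compounds shown with a change on this ring, and the step is a 1.1-fold lower number from compound 1 to compound 4 (0.02 log units; within the scatter) for chloro in place of hydrogen, which turns 1,3-benzoxazol-2-yl into 5-chloro-1,3-benzoxazol-2-yl. For the compounds shown here, a single chlorine at this place therefore leaves the number within the scatter, while the only step beyond it remains the one on the chain, a 3.7-fold lower number from compound 1 to compound 3 (0.57 log units; beyond the scatter) for the added chain carbon. No measurement available here gives a reason for this result.

Going by these compounds, whether a different group at this place, such as methoxy, an amine or a carboxylic acid, would move the number beyond the scatter remains open. Also open, on these data alone, is whether chloro on this ring would leave the number of compound 3, with its longer chain, just as unmoved.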